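This account rests on a few compounds, and the source may have more. Where it says the series, first, only, none or still open, it means among the compounds named here.

Series notes, measured so far:
compound 1 `Cc1nc(S(C)(=O)=O)ccc1Oc1ncnc(OC2CCN(C(=O)OC3CCC3)CC2)c1F` gives 167 nM
compound 2 `Cc1nc(S(C)(=O)=O)ccc1Oc1ncnc(OC2CCN(C(=O)OC(C)F)CC2)c1F` gives 315 nM
compound 3 `Cc1nc(S(C)(=O)=O)ccc1Oc1ncnc(OC2CCN(C(=O)SC3(C)CC3)CC2)c1F` gives 166 nM

All three were run in a functional assay on isolated protein for inhibition of Glucose-dependent insulinotropic receptor (Rattus norvegicus), read by HTRF and cAMP accumulation; a higher number here means that more compound is needed for the effect, a lower number that less compound is needed. Compound 3, at 166 nM, sits within the scatter of both of the others: a 1.0-fold lower number from compound 1 to compound 3 (0.00 log units; within the scatter) and a 1.9-fold lower number from compound 2 to compound 3 (0.28 log units; within the scatter). The remaining pair behaves the same way, a 1.9-fold higher number from compound 1 to compound 2 (0.28 log units; within the scatter). Nothing among the three moves beyond the scatter.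

Compound 4 `Cc1nc(S(C)(=O)=O)ccc1Oc1ncnc(OC2CCN(C(=O)C(C)(C)F)CC2)c1F` has not yet been measured. Relative to compound 3 the change is a group of 4 heavy atoms (3 carbon, 1 fluorine; no ring) in place of a group of 5 heavy atoms (4 carbon, 1 sulfur; one three-membered non-aromatic ring of carbon only), on a carbonyl carbon. Within the data shown here, the steps that bear on it are the ones that swap the group on the carbonyl carbon: a 1.0-fold lower number from compound 1 to compound 3 (0.00 log units; within the scatter), a 1.9-fold lower number from compound 2 to compound 3 (0.28 log units; within the scatter) and a 1.9-fold higher number from compound 1 to compound 2 (0.28 log units; within the scatter). All were within the scatter, and the nearest acyclic fluoroalkyl case, compound 2 with its 1-fluoroethyl group, gave 315 nM. Compound 4 is therefore expected to move little, at most slightly towards a higher number, a 1.4-fold higher number from compound 3 to compound 4 (0.16 log units; within the scatter). The estimate for compound 4 in this assay is 240 nM, with a range from 100 nM to 600 nM.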

Compound 4, half-maximal effective concentration: 296 nM
Estimate against measurement, compound 4: 1.2-fold (0.09 log units) below; low and high end bracket the measured number.
By their numbers in this assay, from the lowest: compounds 3, 1, 4 and 2 (each within the scatter of the next).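

In this assay the carbonyl carbon now carries 1-fluoro-1-methylethyl, a group with neither oxygen nor sulfur, and every new step stays within the scatter: a 1.8-fold higher number from compound 3 to compound 4 (0.25 log units; within the scatter) and a 1.8-fold higher number from compound 1 to compound 4 (0.25 log units; within the scatter) and a 1.1-fold lower number from compound 2 to compound 4 (0.03 log units; within the scatter). The oxygen or sulfur of the groups in compounds 1, 2 and 3 is therefore not required at this position for a value in this range, and the ring-free compound 4 cannot be told apart from the ring-bearing compounds 1 and 3. Nothing available explains this tolerance.

The compounds shown leave open whether the fluorine of 1-fluoro-1-methylethyl matters, since plain isopropyl does not appear among them. Going by these compounds, it is also open whether an amine on the carbonyl carbon, or a longer fluoroalkyl chain, would move the number beyond the scatter.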